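A few compounds are considered here, and "the series" means these few. Any claim that something is new, unique, unknown or untested is made for them only; others in the source may bear on it.

Measured so far in a functional assay for agonist activity at growth hormone secretagogue receptor type 1 (Homo sapiens), read by FLIPR; on this read-out higher numbers stand for an effect only at larger amounts of compound and lower numbers for an effect already at smaller amounts:
- compound 1 `COc1cc2c(cc1N1C[C@@H](C)N(C)[C@@H](C)C1)N(S(=O)(=O)c1cccc(Br)c1)CC2`: 126 nM
- compound 2 `COc1cc2c(cc1N1C[C@@H](C)N[C@@H](C)C1)N(S(=O)(=O)c1ccc(-c3ccccn3)cc1)CC2`: 0.2 nM
- compound 3 `COc1cc2c(cc1N1CCNCC1)N(S(=O)(=O)c1ccc(-c3ccccn3)s1)CC2`: 63.1 nM

Compound 3 sits second highest of the three numbers. Its nearest neighbour is compound 1, whose value lies within the usual scatter of it, so no order between compound 1 and compound 3 is claimed. Compound 2 stands far apart, beyond the scatter, with a much lower number; compound 2 differs from compound 3 in several places at once, so no single change can be read from that pair.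

Compound 4 `COc1cc2c(cc1N1CCNC(C)(C)C1)N(S(=O)(=O)c1ccc(-c3ccccn3)s1)CC2` is the next step: 3,3-dimethylpiperazin-1-yl in place of piperazin-1-yl on an aromatic carbon. For the measured compounds named here, no step between measured compounds isolates this change. The expectation for this assay is a small move toward a lower number, of a size that may well stay inside the scatter. The step expected from compound 3 to compound 4 is a 1.6-fold lower number from compound 3 to compound 4 (0.20 log units; within the scatter). For compound 4 the estimate in this assay is 40 nM, with a range from 8 nM to 200 nM.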

Compound 4, half-maximal effective concentration: 15.9 nM
The estimate for compound 4 lay 2.5-fold (0.40 log units) above the measured number; measured number inside the range.
By their numbers in this assay, from the lowest: compound 2; then compound 4; then compounds 3 and 1 (each within the scatter of the next).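

In this assay, the aromatic carbon ortho to a methoxy group now has its first comparison changing that place alone: 3,3-dimethylpiperazin-1-yl in place of piperazin-1-yl gives a 4.0-fold lower number from compound 3 to compound 4 (0.60 log units; beyond the scatter) as a modest step. The added carbon atoms on the piperazine ring are therefore tolerated in this compound pair. No measured evidence accounts for the step.

Open, from the compounds shown here alone, is how a single methyl group or a morpholin-4-yl ring would read at this position. Also open, going by these compounds, is whether the step carries over with other sulfonyl groups.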